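The source may report more compounds than this note shows. Statements on the series, on what has been measured and on what is new or still open speak of the compounds shown alone.

Compound 1 `C/N=C(\S)OC[C@H]1OC(n2cnc3c(NC4CCOC4)ncnc32)[C@H](O)[C@@H]1O`: 45 nM
Compound 2 `CCNC(=O)OC[C@H]1OC(n2cnc3c(NC4CCOC4)ncnc32)[C@H](O)[C@@H]1O`: 167 nM

Among the compounds with values here, in an assay on DDT1 cells (Cricetulus griseus) for binding affinity to adenosine receptor A1 (Homo sapiens), read by radioligand binding (a lower number here means a stronger inhibitor, a higher number a weaker inhibitor), compound 1 gives 45 nM, the lowest of the two numbers measured so far, while compound 2 gives 167 nM; the step of a 3.7-fold higher number from compound 1 to compound 2 (0.57 log units; beyond the scatter) lies beyond the usual scatter. Compound 3 `O[C@@H]1[C@@H](CO/C(S)=N/C2CCCC2)OC(n2cnc3c(NC4CCOC4)ncnc32)[C@@H]1O` keeps the whole of compound 1 except for one change: cyclopentyl in place of methyl on a double-bonded nitrogen. Within the data shown here, the only measured step, a 3.7-fold higher number from compound 1 to compound 2 (0.57 log units; beyond the scatter), exchanges the group sitting on an oxygen on a saturated carbon and leaves the double-bonded nitrogen untouched, so it does not speak to this change. No measured comparison therefore guides the expectation, and a step within the scatter, in either direction, is the plainest reading. Compound 3 is expected to give about 35 nM, within a range of 9 nM to 140 nM. That estimate corresponds to an expected step of a 1.3-fold lower number from compound 1 to compound 3 (0.11 log units; within the scatter).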

Compound 3, inhibition constant: 72 nM
The estimate for compound 3 lay 2.1-fold (0.31 log units) below the measured number, and the stated range covers the measured number.
By their numbers in this assay, from the lowest: compounds 1 and 3 (each within the scatter of the next); then compound 2.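

In this assay, the double-bonded nitrogen accepts a far bulkier group than methyl with no clear loss: cyclopentyl in place of methyl gives a 1.6-fold higher number from compound 1 to compound 3 (0.20 log units; within the scatter), so the two compounds cannot be told apart. The step of a 2.3-fold lower number from compound 2 to compound 3 (0.37 log units; beyond the scatter) shows that the sulfur-bearing group keeps its advantage over the oxygen-bearing group once it carries the ring, as it did with methyl, although sulfur and ring change together in this step. Nothing available explains either result.

On these data alone, it remains open whether a phenyl ring or a longer chain such as hexyl on the double-bonded nitrogen would give a similar number. Also open, as far as these compounds go, is how much of the second step belongs to sulfur alone and how much to the cyclopentyl ring.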